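The compounds below may be only part of what the source reports. "The series", "measured", "known", "first", "only" and "open" are said of these compounds alone.

Compound 3 `COc1cc(C2CC(c3cc4ccccc4o3)=NN2C(=O)Nc2ccc(O)cc2)ccc1O` stands lowest of the three compounds measured in a functional assay on microsomes from liver (Rattus norvegicus, strain Wistar) for inhibition, with a stated time of 15 min (a higher number here means a weaker inhibitor, a lower number a stronger inhibitor), with 15000000 nM as its half-maximal inhibitory concentration. Compound 1 `COc1cc(C2CC(c3cc4ccccc4o3)=NN2C(=O)Nc2ccc([N+](=O)[O-])cc2)ccc1O` gives 113000000 nM and compound 2 `COc1cc(C2CC(c3cc4ccccc4o3)=NN2C(=O)Nc2ccc(Cl)cc2)ccc1O` gives 121000000 nM in the same test, and the step between them (a 1.1-fold higher number from compound 1 to compound 2 (0.03 log units; within the scatter)) lies within the scatter. Hydroxy on the outer ring goes with a lower number in both remaining steps (a 7.5-fold lower number from compound 1 to compound 3 (0.88 log units; beyond the scatter)) and (an 8.1-fold lower number from compound 2 to compound 3 (0.91 log units; beyond the scatter)). Compound 4 `COc1cc(C2CC(c3cc4ccccc4o3)=NN2C(=O)Cl)ccc1O` has chloro in place of (4-hydroxyphenyl)amino on a carbonyl carbon and so loses that hydroxy along with its ring. Within the data shown here, no measured step removes the whole group, so those two steps are only a rough guide, and a modest rise is expected in this assay. The expected step (a 3.3-fold higher number from compound 3 to compound 4 (0.52 log units; beyond the scatter)) is similar to them or somewhat smaller. For compound 4 the estimated value is 50000000 nM within a range of (10000000 nM to 200000000 nM).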

Compound 4, half-maximal inhibitory concentration: 147000000 nM
The estimate for compound 4 lay 2.9-fold (0.47 log units) below the measured number, and the stated range covers the measured number.
By their numbers in this assay, from the lowest: compound 3; then compounds 1, 2 and 4 (each within the scatter of the next).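

In this assay, chloro in place of (4-hydroxyphenyl)amino on the carbonyl carbon gives a clear rise (a 9.8-fold higher number from compound 3 to compound 4 (0.99 log units; beyond the scatter)). Replacing the (4-chlorophenyl)amino group (a 1.2-fold higher number from compound 2 to compound 4 (0.08 log units; within the scatter)) or the (4-nitrophenyl)amino group (a 1.3-fold higher number from compound 1 to compound 4 (0.11 log units; within the scatter)) in the same way changes nothing beyond the scatter, so among these four compounds the outer ring matters only when it carries hydroxy. Nothing available explains why this is so. From the compounds shown here alone, it remains open whether an amine or a carboxylic acid in place of that hydroxy would also give a lower number.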